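The source may hold more compounds than are shown below. What is called first, only, known or untested is meant among the compounds shown, and "the series" means these compounds.

Compound 1 `COc1cc2nc(N3CCN(S(=O)(=O)c4ccc(I)cc4)CC3)nc(N)c2cc1OC` gives 15000 nM in a functional assay on PC-3 cells (Homo sapiens) for inhibition; on this read-out lower numbers stand for stronger inhibition and higher numbers for weaker inhibition.
Compound 2 `COc1cc2nc(N3CCN(S(=O)(=O)c4ccc(Cl)s4)CC3)nc(N)c2cc1OC` gives 25000 nM.
Compound 3 `COc1cc2nc(N3CCN(S(=O)(=O)c4cccc5ccccc45)CC3)nc(N)c2cc1OC` gives 14000 nM.

Compound 1 has the second highest of these three numbers, but it is not separated from either neighbour: a 1.1-fold lower number from compound 1 to compound 3 (0.03 log units; within the scatter) and a 1.7-fold higher number from compound 1 to compound 2 (0.22 log units; within the scatter) both lie within the scatter. Compound 4 `COc1cc2nc(N3CCN(S(=O)(=O)c4ccc(-c5ccc(C)cc5)cc4)CC3)nc(N)c2cc1OC` differs from compound 1 by 4-methylphenyl in place of iodo on an aromatic carbon. Among the measured compounds shown here, all three measured steps swap the group on the sulfonyl sulfur, and each of them, a 1.7-fold higher number from compound 1 to compound 2 (0.22 log units; within the scatter), a 1.1-fold lower number from compound 1 to compound 3 (0.03 log units; within the scatter) and a 1.8-fold lower number from compound 2 to compound 3 (0.25 log units; within the scatter), stays within the scatter; none of them brings in a 4-methylphenyl, so the new change has no direct precedent. A step no larger than the scatter is therefore expected, a 1.3-fold lower number from compound 1 to compound 4 (0.10 log units; within the scatter). Compound 4 is estimated at 12000 nM, between 4500 nM and 32000 nM.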

Compound 4, half-maximal inhibitory concentration: 3400 nM
Compound 4: middle estimate off by 3.5-fold (0.55 log units), on the high side, outside the stated range (below it).
By their numbers in this assay, from the lowest: compound 4; then compounds 3, 1 and 2 (each within the scatter of the next).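

In this assay, among the compounds shown here, replacing iodo with 4-methylphenyl gives a 4.4-fold lower number from compound 1 to compound 4 (0.64 log units; beyond the scatter), the only step so far that lies beyond the scatter. The earlier steps shown here all changed the group on the sulfonyl sulfur, whereas this one shows that inhibition responds to a change on the aromatic carbon para to a large group. No available evidence explains this gain.

Going by these compounds, it remains open whether an unsubstituted phenyl, a 4-methoxyphenyl or a small amine at this place would give similar inhibition.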